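The compounds below may be only part of what the source reports. "The series", "measured", "known", "first", "only" and "open" are said of these compounds alone.

Measured so far in a functional assay on HT cells (Homo sapiens) for antiproliferative activity, read by fluorescence, with a stated time of 72 h; on this read-out lower numbers stand for stronger inhibition of growth and higher numbers for weaker inhibition of growth:
- compound 1 `CC(C)c1n[nH]c2c(NCc3ccc(-c4ccccn4)cc3)nc(SCC3CNC(=O)O3)nc12`: 80 nM
- compound 2 `CC(O)CSc1nc(NCc2ccc(-c3ccccn3)cc2)c2[nH]nc(C(C)C)c2n1`: 62 nM

Within the data shown here, compound 2 at 62 nM and compound 1 at 80 nM lie within the scatter of each other, so these two numbers give no ranking and place compound 2 simply level with the only other measured compound.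

Next in the series is compound 3 `CC(C)c1n[nH]c2c(NCc3ccc(-c4ccccn4)cc3)nc(SC(CO)C(C)C)nc12`, which differs from compound 2 as follows: 1-(hydroxymethyl)-2-methylpropyl in place of 2-hydroxypropyl on a sulfur. In words, 1-(hydroxymethyl)-2-methylpropyl stands in place of 2-hydroxypropyl on a sulfur.

Among the measured compounds shown here, one measured step bears on this, since it also alters the chain on that sulfur: a 1.3-fold lower number from compound 1 to compound 2 (0.11 log units; within the scatter). That step stays within the scatter, although the ring-bearing chain of compound 1 gave way to an open chain. For the measured compounds named here, no measured compound carries 1-(hydroxymethyl)-2-methylpropyl, so this single step is thin support, and the range has to stay wide.

In this assay no step beyond the scatter is expected in either direction, and the expected step is a 1.0-fold lower number from compound 2 to compound 3 (0.01 log units; within the scatter) for now. For compound 3 the estimated value is 60 nM, with an expected range of 25 nM to 150 nM.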

Compound 3, concentration for 50% growth inhibition: 980 nM
The estimate for compound 3 lay 16-fold (1.21 log units) below the measured number; the whole stated range lies below it.
By their numbers in this assay, from the lowest: compounds 2 and 1 (each within the scatter of the next); then compound 3.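

Working from this assay, the chain on the sulfur proves far less forgiving than the earlier pair suggested: a 1.3-fold lower number from compound 1 to compound 2 (0.11 log units; within the scatter) stayed within the scatter, yet the new chain gives a 16-fold higher number from compound 2 to compound 3 (1.20 log units; beyond the scatter) and, against the ring-bearing chain, a 12-fold higher number from compound 1 to compound 3 (1.09 log units; beyond the scatter) in the same direction. Compound 3 therefore stands apart from both earlier compounds, so the loss is not tied to one particular departing chain, and an open chain with a hydroxyl group is not enough to hold the number near that of compound 2. Between compound 2 and compound 3 the counted hydrogen-bond donors and acceptors stay the same and neither chain has a ring or net charge, while the heavy atoms go from 4 to 6, and no measurement here explains the size of the step.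

Since the carbon skeleton and the place of the hydroxyl both change together in compound 3, the shown compounds do not separate these two changes. A 2-hydroxyethyl chain, a 3-hydroxypropyl chain, or a chain ending in an amine or a carboxylic acid on the same sulfur would show how far this sensitivity extends.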